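The compounds below may be only part of what the source reports. "The series", "measured", "known", "first", "only" and "open" are said of these compounds alone.

The study covers three compounds that share one core. Compound 1 `COc1ccc(/C=C\C(=O)O)c(OCc2cn(-c3ccccc3F)nn2)c1CC=C(C)C` has no reported number: in a functional assay on HCT-116 cells (Homo sapiens) for cytotoxicity, read by MTT assay, with a stated time of 24 h (a higher number here means a weaker inhibitor, a lower number a stronger inhibitor), compound 1 is given as "not determined" (no result reported). Compound 2 `COc1ccc(/C=C\C(=O)O)c(OCc2cn(-c3cccc([N+](=O)[O-])c3)nn2)c1CC=C(C)C` carries the only number shown: in this assay compound 2 gives 27300 nM, so it stands alone on the numbers and cannot be ranked against anything else. Compound 3 `COc1ccc(/C=C\C(=O)O)c(OCc2cn(-c3ccccc3C#N)nn2)c1CC=C(C)C` has not yet been measured. It differs from compound 2 in a single place, (2-cyanophenyl in place of 3-nitrophenyl on an aromatic nitrogen), that is, 2-cyanophenyl in place of 3-nitrophenyl on an aromatic nitrogen of a five-membered aromatic ring with 3 nitrogen. Going by the values given here, no step between two measured compounds is available, so the data give no sign of how this exchange moves potency. The step that the estimate means, a 1.0-fold lower number from compound 2 to compound 3 (0.00 log units; within the scatter), is therefore expected to be none beyond the scatter. Compound 3 is expected to give about 27000 nM in this assay, with a likely range from 9000 nM to 80000 nM.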

Compound 3, half-maximal inhibitory concentration: 38300 nM
Compound 3: middle estimate off by 1.4-fold (0.15 log units), on the low side; the measured number falls inside the stated range.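

On the aromatic nitrogen of the five-membered ring, the exchange of 3-nitrophenyl for 2-cyanophenyl in this assay comes out as a 1.4-fold higher number from compound 2 to compound 3 (0.15 log units; within the scatter), so the two compounds cannot be told apart. Going by these compounds alone, this is the first step that can be read at this place, and it shows that two different substituted phenyl groups, one with a nitro group and one with a nitrile, give readings within the scatter of each other. Nothing measured on these compounds speaks to why they read alike.

Within the data shown here, compound 1 gives "not determined" (no result reported), so no step involving it can be read. Going by these compounds, whether an aminophenyl group, a benzyl group or a plain alkyl chain on the same nitrogen would shift the number beyond the scatter remains open.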